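Ester chain variation in the cyanoguanidine series at the A3 receptor

This account rests on a few compounds, and the source may have more. Where it says the series, first, only, none or still open, it means among the compounds named here.

Measured so far:
compound 1 `CC1=C(C(=O)OC(C)C)C(C2CCCC2)N/C(=N/C#N)N1`: 3%
compound 2 `CC1=C(C(=O)OC(C)C)C(c2ccsc2)N/C(=N/C#N)N1`: 13%
compound 3 `CCOC(=O)C1=C(C)N/C(=N\C#N)NC1c1ccco1`: 20%

In an assay on HeLa cells for displacement of a labelled ligand from adenosine receptor A3 (Homo sapiens), with a stated time of 180 min, tested at 1 uM (a higher number here means more inhibition at the concentration tested (going by the name of the read-out), a lower number less inhibition), compound 3 gives 20%. Its gap to compound 2 lies within the scatter; only its gap to compound 1 lies beyond it. Going by the values given here, the single one-place step, a number 10 percentage points higher from compound 1 to compound 2 (within the scatter), concerns the group on the saturated ring carbon and is within the scatter. Compound 4 `CC1=C(C(=O)OC(C)C)C(c2ccco2)N/C(=N/C#N)N1` differs from compound 3 by methyl in place of hydrogen on a saturated chain carbon bound to an oxygen next to a carbonyl group and a saturated chain carbon. Among the compounds with values here, no measured pair changes this place, so nothing bears on it directly; given that the one step seen is within the scatter, no step beyond the scatter is expected here either. For compound 4 the estimate is 20%, range 8% to 32%, corresponding to an expected no change at the digits printed from compound 3 to compound 4 (within the scatter).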

Compound 4, a percentage reported as inhibition, at one concentration (the size of the read-out at that concentration, not a potency): 4%
Estimate against measurement, compound 4: 16 percentage points above, outside the stated range (below it).
By their numbers in this assay, from the lowest: compounds 1, 4, 2 and 3 (each within the scatter of the next, the first and the last beyond it).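

In this assay, going by these compounds alone, ethyl to isopropyl in the ester gives a number 16 percentage points lower from compound 3 to compound 4 (beyond the scatter) with furan-2-yl unchanged, the first reading at this place. With isopropoxycarbonyl kept, furan-2-yl on the saturated ring carbon gives a number 9 percentage points lower from compound 2 to compound 4 (within the scatter) and a number 1 percentage points higher from compound 1 to compound 4 (within the scatter) so that ring carbon has yet to show a step beyond the scatter. Nothing measured here accounts for the ester step.

From the compounds shown here alone, whether that step holds with thiophen-3-yl or cyclopentyl on the ring carbon stays open. So does the effect of a methyl ester or a longer chain such as butyl at this place.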